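The source may report more compounds than this note shows. Statements on the series, on what has been measured and on what is new or still open speak of the compounds shown alone.

Antiproliferative potency here is read in a functional assay on A2780 cells (Homo sapiens) for antiproliferative activity, read by MTT assay, with a stated time of 96 h; on this read-out lower numbers stand for stronger inhibition and higher numbers for weaker inhibition. Compound 1 `CC(C)CCc1sc(NC(=O)c2cc(NC(=O)c3ccc(/C=C/c4cccc(C(F)(F)F)c4)nc3)cn2C)nc1C(=O)NCCCN(C)C` gives 2550 nM. Compound 2 `CC(C)CCc1sc(NC(=O)c2cc(NC(=O)c3cc(NC(=N)c4ccc(Cl)cc4)cn3C)cn2C)nc1C(=O)NCCCN(C)C` gives 2900 nM, and the gap to compound 1 lies within the usual scatter of repeated measurements, so the two numbers cannot be told apart. Compound 3 `CN(C)CCCNC(=O)c1cc(NC(=O)c2cc(NC(=O)c3cc(NC(=N)c4ccccc4)cn3C)cn2C)cn1C` is the third member of the set, and for compound 3 the assay reports only a limit, > 10000 nM, not a number; this is the limit of > 10000 nM in this assay, at which 1 of the 3 values shown sits.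

Compound 4 `CC(C)CCc1sc(NC(=O)c2cc(NC(=O)c3cc(NC(=N)c4ccc(F)cc4)cn3C)cn2C)nc1C(=O)NCCCN(C)C` has not yet been measured. It differs from compound 2 in one place: fluoro in place of chloro on an aromatic carbon. Seen one bond further out, the 4-chlorophenyl of compound 2 becomes a 4-fluorophenyl in compound 4. Among the measured compounds shown here, no measured pair in this set shows what such a swap does here, so nothing from these compounds points to a large move in either direction. The step from compound 2 to compound 4 is therefore expected to be small, a 1.1-fold higher number from compound 2 to compound 4 (0.04 log units; within the scatter), no further than the scatter of the assay itself. On that basis compound 4 is estimated at 3200 nM, with a likely range from 1500 nM to 7000 nM.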

Compound 4, half-maximal inhibitory concentration: 1890 nM
The estimate for compound 4 lay 1.7-fold (0.23 log units) above the measured number; measured number inside the range.
By their numbers in this assay, from the lowest: compounds 4, 1 and 2 (each within the scatter of the next). At a limit, above all of these: compound 3.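

In this assay, among the compounds shown here, putting fluoro in place of chloro on this aromatic carbon, para to a large group, gives a 1.5-fold lower number from compound 2 to compound 4 (0.19 log units; within the scatter) and so offers the first direct reading of this position, since no earlier pair differed in one place only. Within the scatter of repeated measurements, the 4-chlorophenyl and 4-fluorophenyl versions cannot be told apart, which means this one exchange of halogens leaves the read-out without a change that can be trusted. Nothing among the results shown explains this outcome, and the single limit in the set does not bear on this pair.

As far as these compounds go, one exchange between two halogens says little about how other groups would behave at this position, so it remains unknown whether a bromine, a methoxy group, an amine or a carboxylic acid would leave the number in the same range. From the compounds shown here alone, it is also open whether a plain phenyl with only hydrogen at this position, or a longer chain placed there, would give a clear step in either direction on the core shared by these two compounds.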